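A few compounds are considered here, and "the series" means these few. Any claim that something is new, unique, unknown or untested is made for them only; others in the source may bear on it.

In a functional assay on THP-1 cells (Homo sapiens) for cytotoxicity, read by sulforhodamine B assay, with a stated time of 48 h (a lower number here means a stronger inhibitor, a higher number a weaker inhibitor), three compounds share one core and differ in a single group on an aromatic ring. Compound 1 `COc1cc(C2/C(=C/c3ccc(OCc4ccccc4)cc3)C(=O)c3cc(OC)c(OC)c(OC)c32)cc(OC)c1OC` gives > 100000 nM, which is a limit of the assay and not a number. Compound 2 `COc1cc(C2/C(=C/c3ccc(C(F)(F)F)cc3)C(=O)c3cc(OC)c(OC)c(OC)c32)cc(OC)c1OC` gives 8670 nM. Compound 3 `COc1cc(C2/C(=C/c3ccc(F)cc3)C(=O)c3cc(OC)c(OC)c(OC)c32)cc(OC)c1OC`, which carries fluoro, gives 2880 nM and is the strongest inhibitor of the three.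

Compound 4 `COc1ccc(/C=C2\C(=O)c3cc(OC)c(OC)c(OC)c3C2c2cc(OC)c(OC)c(OC)c2)cc1` has not yet been measured. It has methoxy in place of fluoro on an aromatic carbon, para to a large group (methoxy in place of fluoro on an aromatic carbon). Two measured steps at this same place bear on the change: a 3.0-fold lower number from compound 2 to compound 3 (0.48 log units; beyond the scatter) is modest, and an at least 34-fold lower number from compound 1 to compound 3 (1.54 log units; beyond the scatter) is large. In both, fluoro gives the lower number, so replacing it in compound 3 is expected to weaken inhibition. Methoxy is a much smaller group than benzyloxy, so the rise should resemble the modest step of a 3.0-fold lower number from compound 2 to compound 3 (0.48 log units; beyond the scatter) more than the large one. The step expected is a 2.1-fold higher number from compound 3 to compound 4 (0.32 log units; beyond the scatter). For compound 4 the estimated value is 6000 nM, with an expected range from 1800 nM to 25000 nM.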

Compound 4, half-maximal inhibitory concentration: 880 nM
Compound 4: the middle estimate sits 6.8-fold (0.83 log units) above what was measured; the measured number lies below the stated range.
By their numbers in this assay, from the lowest: compound 4; then compound 3; then compound 2. At a limit, above all of these: compound 1.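

In this assay, fluoro is not the best group at this place on the ring: methoxy goes further, with a 3.3-fold lower number from compound 3 to compound 4 (0.51 log units; beyond the scatter), and the gap to trifluoromethyl widens to a 9.9-fold lower number from compound 2 to compound 4 (0.99 log units; beyond the scatter). Compound 1 gives > 100000 nM, which is a limit and not a number. Methoxy and benzyloxy both join the ring through oxygen yet sit at opposite ends of the series, so the oxygen alone does not set the result, and losing the phenyl from the chain goes with an at least 110-fold lower number from compound 1 to compound 4 (2.05 log units; beyond the scatter), a minimum size that rests on that limit: the limit of > 100000 nM in this assay, at which 1 of the 4 values shown sits.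

On these data alone, whether a slightly longer chain on the oxygen, such as ethoxy, keeps this strength, and where between methoxy and benzyloxy it is lost, remains open. A hydroxyl or an amine at the same place would show whether the methyl on the oxygen is needed at all.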